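The source may report more compounds than this note shows. Statements on the series, on what has been measured and on what is new or still open speak of the compounds shown alone.

Compound 2 `CN1CCN(CCCCOc2c(OCc3nc4ccccc4o3)cc(O)c3c(=O)cc(-c4ccccc4)oc23)CC1` and compound 1 `Cc1ccc(COc2cc(O)c3c(=O)cc(-c4ccccc4)oc3c2OCCCCN2CCN(C)CC2)cc1` share one core and differ only at the group on a saturated chain carbon bound to an oxygen on an aromatic ring. In a functional assay on A549 cells (Homo sapiens) for cytotoxicity, read by MTT assay, with a stated time of 72 h (a lower number here means a stronger inhibitor, a higher number a weaker inhibitor), compound 2 gives 3870 nM, and compound 1 gives 3200 nM; the gap between them lies within the scatter. Compound 3 `CN1CCN(CCCCOc2c(OCc3nc4ccccc4s3)cc(O)c3c(=O)cc(-c4ccccc4)oc23)CC1` differs from compound 2 by 1,3-benzothiazol-2-yl in place of 1,3-benzoxazol-2-yl on a saturated chain carbon bound to an oxygen on an aromatic ring. Within the data shown here, the only step that bears on this change is a 1.2-fold higher number from compound 1 to compound 2 (0.08 log units; within the scatter), a swap at the same place that did not move the number beyond the scatter. A step of that kind is expected again, a 1.1-fold lower number from compound 2 to compound 3 (0.04 log units; within the scatter), nothing beyond the scatter. Compound 3 is expected to give 3500 nM, with a range from 1500 nM to 8000 nM.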

Compound 3, half-maximal inhibitory concentration: 1060 nM
Compound 3: the middle estimate sits 3.3-fold (0.52 log units) above what was measured, outside the stated range (below it).
By their numbers in this assay, from the lowest: compound 3; then compounds 1 and 2 (each within the scatter of the next).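

At this position, on a saturated chain carbon bound to an oxygen on an aromatic ring, the group does matter: in this assay, swapping the oxygen-containing 1,3-benzoxazol-2-yl for the sulfur-containing 1,3-benzothiazol-2-yl gives a 3.7-fold lower number from compound 2 to compound 3 (0.56 log units; beyond the scatter). The 1,3-benzothiazol-2-yl group also separates from 4-methylphenyl, with a 3.0-fold lower number from compound 1 to compound 3 (0.48 log units; beyond the scatter), although the earlier pair stayed within the scatter. Nothing available explains this shift. Going by these compounds, how an amine or a carboxylic acid in this place would compare stays open. So does whether the lower number would hold on another core.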